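The source may hold more compounds than are shown below. What is called first, only, known or untested is meant among the compounds shown, and "the series" means these compounds.

The measured compounds:

Compound 1 `COc1ccc(C(=O)Nc2ccc(Cl)cc2F)c(OCc2ccc(F)cc2F)c1` gives > 40000 nM in an ADME assay on RAW264.7 cells (Mus musculus) for cytotoxicity, read by MTT assay, with a stated time of 24 h (a higher number here means that more compound is tolerated, a lower number that less compound is tolerated), a limit of the assay rather than a number.
Compound 2 `O=C(Nc1ccc(F)cc1F)c1ccccc1OCc1ccc(F)cc1F` gives > 40000 nM in this assay, again a limit of the assay.
Compound 3 `O=C(Nc1ccc(I)cc1F)c1ccccc1OCc1ccc(F)cc1F` gives 32600 nM in this assay.

Within the data shown here, compound 3 thus carries the only actual number among the three; the other two results sit at the limit of > 40000 nM in this assay, at which 2 of the 3 values shown sit. Among the measured compounds shown here, the one measured step, an at least 1.2-fold lower number from compound 2 to compound 3 (0.08 log units; that floor lies within the scatter), runs from a limit to a number, and its floor lies within the scatter, so it shows no clear change in tolerance.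

Compound 4 `COc1ccc(C(=O)Nc2ccc(I)cc2F)c(OCc2ccc(F)cc2F)c1` differs from compound 3 in a single place: methoxy in place of hydrogen on an aromatic carbon. For the measured compounds named here, no measured step concerns a methoxy group. Compound 1 and compound 2 differ from each other in two places at once, and both give only a limit, so they show nothing about the methoxy group on its own. Going by the values given here, with no step to lean on, compound 4 is expected to sit close to compound 3 in this assay, with no step beyond the scatter.

On that basis the step from compound 3 to compound 4 is estimated as a 1.1-fold higher number from compound 3 to compound 4 (0.03 log units; within the scatter).

The value of compound 4 in this assay is therefore estimated at 35000 nM, within a range from 14000 nM to 90000 nM.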

Compound 4, half-maximal cytotoxic concentration: 36800 nM
For compound 4 the middle estimate is 1.1-fold (0.02 log units) below the measured one; measured number inside the range.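

In this assay, the methoxy group now has a step of its own: a 1.1-fold higher number from compound 3 to compound 4 (0.05 log units; within the scatter). Among these compounds, at this place on the ring, meta to a large group and para to a large group, methoxy in place of hydrogen therefore shows no clear difference in how much compound the cells tolerate, which the earlier compounds could not show because the only pair carrying and lacking this group also differed in a second place. The new compound also gives a look at iodo in place of chloro with the methoxy group present, an at least 1.0-fold lower number from compound 1 to compound 4 (0.03 log units; that floor lies within the scatter), but that step runs from a limit to a number and its floor shows no clear change, so it stays open-ended: the limit of > 40000 nM in this assay, at which 2 of the 4 values shown sit.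

Going by these compounds, whether a group other than methoxy at this place, such as an amine, a carboxylic acid or a longer chain on the oxygen, would also leave tolerance without a clear change stays open. On these data alone, how far the chloro and iodo compounds truly lie apart also stays open, since the chloro compound carries only a limit and no number.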